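Hydroxy versus methoxy aryl variation on the hydrazone carbon

The source may report more compounds than this note shows. Statements on the series, on what has been measured and on what is new or still open speak of the compounds shown alone.

Working notes. Within the data shown here, compound 3 `COc1cc(/C=N/NC(=O)Nc2ccc(Oc3ccnc(-c4nncn4CCN(C)C)c3)c(F)c2)cc(OC)c1OC` carries a 3,4,5-trimethoxyphenyl on a carbon with a double bond to nitrogen, and in a functional assay on HT-29 cells (Homo sapiens) for cytotoxicity, read by MTT assay, with a stated time of 72 h (on this read-out higher numbers stand for weaker inhibition and lower numbers for stronger inhibition), compound 3 gives 3620 nM, the highest number of the three measured so far. Compound 1 `CN(C)CCn1cnnc1-c1cc(Oc2ccc(NC(=O)N/N=C/c3cccc(O)c3)cc2F)ccn1`, with 3-hydroxyphenyl at that position, gives 330 nM in this assay; compound 2 `COc1cc(/C=N/NC(=O)Nc2ccc(Oc3ccnc(-c4nncn4CCN(C)C)c3)c(F)c2)ccc1O`, with 4-hydroxy-3-methoxyphenyl, gives 120 nM. The steps that lead to compound 3 are an 11-fold higher number from compound 1 to compound 3 (1.04 log units; beyond the scatter) and a 30-fold higher number from compound 2 to compound 3 (1.48 log units; beyond the scatter); the step between the two hydroxy-bearing analogues is a 2.8-fold lower number from compound 1 to compound 2 (0.44 log units; beyond the scatter).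

Compound 4 `CN(C)CCn1cnnc1-c1cc(Oc2ccc(NC(=O)N/N=C/c3ccc(O)cc3O)cc2F)ccn1` is not yet measured. Its change from compound 3 is 2,4-dihydroxyphenyl in place of 3,4,5-trimethoxyphenyl on a carbon with a double bond to nitrogen. The two steps that bear on this change, both ending at compound 3, were large, and both hydroxy-bearing aryl groups came with far lower numbers, so a return toward that range is anticipated. For compound 4 a large downward step is expected, a 12-fold lower number from compound 3 to compound 4 (1.08 log units; beyond the scatter). In this assay compound 4 is estimated at about 300 nM, with a range from 100 nM to 1200 nM.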

Compound 4, half-maximal inhibitory concentration: 52600 nM
Compound 4: middle estimate off by 180-fold (2.24 log units), on the low side; measured number above the stated range.
By their numbers in this assay, from the lowest: compound 2; then compound 1; then compound 3; then compound 4.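

In this assay, a hydroxy group on this aryl ring does not by itself keep the number low on the carbon with a double bond to nitrogen: the 2,4-dihydroxyphenyl gives a higher number than the hydroxy-free 3,4,5-trimethoxyphenyl (a 15-fold higher number from compound 3 to compound 4 (1.16 log units; beyond the scatter)). The gaps to the two hydroxy-bearing analogues are wider still (a 160-fold higher number from compound 1 to compound 4 (2.20 log units; beyond the scatter); a 440-fold higher number from compound 2 to compound 4 (2.64 log units; beyond the scatter)), so across these four compounds the read-out follows the full substitution pattern of the aryl ring, not the mere presence of hydroxy. No measurement at hand accounts for this reversal.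

The compounds shown do not separate the contributions of the two hydroxy groups of the 2,4-dihydroxyphenyl. Going by these compounds, how an aryl ring bearing a dimethylamino group or a carboxylic acid would read at this place also remains open.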